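The source may report more compounds than this note shows. Statements on the series, on what has been measured and on what is new or still open speak of the compounds shown alone.

In a functional assay on A549 cells (Homo sapiens) for cytotoxicity, with a stated time of 48 h (a higher number here means a weaker inhibitor, a lower number a stronger inhibitor), compound 1 (`CC(C)CC(=O)Oc1ccc2oc(/C=C/[S+](C)[O-])cc(=O)c2c1`) gives 2300 nM. Compound 2 (`COc1ccc2c(=O)cc(/C=C/[S+](C)[O-])oc2c1`) gives 2200 nM, and compound 3 (`Cc1c(/C=C/[S+](C)[O-])oc2ccccc2c1=O`) gives 1500 nM. These three values lie within the scatter of one another, so compound 1 stands level with the other two. Compound 4 (`C[S+]([O-])/C=C/c1cc(=O)c2cc(Cl)ccc2o1`) has not yet been measured. It differs from compound 1 by chloro in place of (isobutylcarbonyl)oxy on an aromatic carbon, with chloro in place of (isobutylcarbonyl)oxy on an aromatic carbon. Within the data shown here, no measured step isolates this change, but the three measured compounds, each substituted differently, sit close together. No step beyond the scatter is therefore expected in this assay, in either direction. The expected 1.3-fold lower number from compound 1 to compound 4 (0.11 log units; within the scatter) stays within the scatter. For compound 4 the estimate is 1800 nM, with an expected range of 800 nM to 4000 nM.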

Compound 4, half-maximal inhibitory concentration: 1700 nM
For compound 4 the middle estimate is 1.1-fold (0.02 log units) above the measured one; the range from low to high includes it.
By their numbers in this assay, from the lowest: compounds 3, 4, 2 and 1 (each within the scatter of the next).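

Replacing (isobutylcarbonyl)oxy with chloro on this aromatic carbon gives a 1.4-fold lower number from compound 1 to compound 4 (0.13 log units; within the scatter) in this assay. Among these compounds, this is the first comparison that isolates a single place, and it shows that the seven heavy atoms of the ester group, with its two hydrogen-bond acceptors, can give way to one chlorine without a step beyond the scatter. No measurement shown here offers an explanation for this result. As far as these compounds go, whether an amine or a carboxylic acid on this carbon would also stay level with compound 1 remains open. So does the effect of a longer chain there.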